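From methylsulfanyl to (2-aminocyclohexyl)amino on a shared core

This account rests on a few compounds, and the source may have more. Where it says the series, first, only, none or still open, it means among the compounds named here.

Measured in a functional assay on G-361 cells (Homo sapiens) for cytotoxicity, read by fluorescence, with a stated time of 72 h; on this read-out higher numbers stand for weaker inhibition and lower numbers for stronger inhibition:
- Compound 1 `CSc1nc(NCc2ccc(-c3ccccn3)cc2)c2[nH]nc(C(C)C)c2n1`: 1400 nM
- Compound 2 `CC(C)c1n[nH]c2c(NCc3ccc(-c4ccccn4)cc3)nc(NCCO)nc12`: 39 nM
- Compound 3 `CC(C)c1n[nH]c2c(NCc3ccc(-c4ccccn4)cc3)nc(NCCN)nc12`: 230 nM

Compound 1 has the highest number of the three, so it is the weakest inhibitor here. Compound 4 `CC(C)c1n[nH]c2c(NCc3ccc(-c4ccccn4)cc3)nc(N[C@@H]3CCCC[C@H]3N)nc12` keeps the core of compound 1 but has (2-aminocyclohexyl)amino in place of methylsulfanyl on an aromatic carbon. Two measured steps make the same kind of swap, with open chains instead of a ring. The first is large, a 36-fold lower number from compound 1 to compound 2 (1.56 log units; beyond the scatter), and the second modest, a 6.1-fold lower number from compound 1 to compound 3 (0.78 log units; beyond the scatter). Neither step tests a ring, so the expectation stays loose: a clear drop in this assay, of a size within or near that span. The expected step is an 18-fold lower number from compound 1 to compound 4 (1.24 log units; beyond the scatter). For compound 4 the estimated value is 80 nM, with an expected range of 20 nM to 300 nM.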

Compound 4, half-maximal inhibitory concentration: 477 nM
The estimate for compound 4 lay 6.0-fold (0.78 log units) below the measured number; measured number outside the range, above it.
By their numbers in this assay, from the lowest: compound 2; then compound 3; then compound 4; then compound 1.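

In this assay, replacing methylsulfanyl with the ring-bearing group still lowers the number, with a 2.9-fold lower number from compound 1 to compound 4 (0.47 log units; beyond the scatter), but the ring falls behind both open chains, with a 2.1-fold higher number from compound 3 to compound 4 (0.32 log units; beyond the scatter) and a 12-fold higher number from compound 2 to compound 4 (1.09 log units; beyond the scatter). So this position accepts a six-membered non-aromatic ring, though this group gives the smallest gain over methylsulfanyl of the three amino groups shown. Nothing measured here gives a reason for these differences.

From the compounds shown here alone, the other arrangements of the two stereocentres remain open. So does (2-hydroxycyclohexyl)amino, which would show whether hydroxy outperforms amino on the ring as it does on the open chain.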